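From Formyl to Fluoro on the Shared Core

The source may report more compounds than this note shows. Statements on the series, on what has been measured and on what is new or still open speak of the compounds shown alone.

Measured compounds:
Compound 1 `COc1ccc(-c2cn3ccnc3c(-c3ccc4ncn(C5CCCCC5)c4c3)n2)cc1`: -43.4%
Compound 2 `O=Cc1ccc(-c2cn3ccnc3c(-c3ccc4ncn(C5CCCCC5)c4c3)n2)cc1`: 31.5%

Both compounds were tested in a functional assay on SF-539 cells (Homo sapiens) for inhibition, read by sulforhodamine B assay, with a stated time of 48 h, tested at 10 uM; on this read-out higher numbers stand for more inhibition at the one concentration tested (going by the name of the read-out) and lower numbers for less inhibition. Compound 1 gives -43.4%, and compound 2 gives 31.5%. For the measured compounds named here, compound 2 therefore stands highest of the two, with compound 1 as its only neighbour, a step of a number 74.9 percentage points higher from compound 1 to compound 2 (beyond the scatter) away.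

The next compound, compound 3 `Fc1ccc(-c2cn3ccnc3c(-c3ccc4ncn(C5CCCCC5)c4c3)n2)cc1`, keeps the shared core and differs from compound 2 in a single place: fluoro in place of formyl on an aromatic carbon.

Going by the values given here, only one measured step bears on this change. That step, from methoxy to formyl at the same position, was a number 74.9 percentage points higher from compound 1 to compound 2 (beyond the scatter), so this position is clearly sensitive to what sits on it. Among the compounds with values here, no measured pair shows what fluoro does there, and fluoro resembles neither of the two groups already seen. The expectation is therefore wide: compound 3 is expected to fall back from compound 2 by a number 36.5 percentage points lower from compound 2 to compound 3 (beyond the scatter), landing somewhere between the two measured values. Compound 3 is thus estimated at -5%, with a range from -45% to 35%.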

Compound 3, a percentage reported as inhibition, at one concentration (the size of the read-out at that concentration, not a potency): 17.3%
The estimate for compound 3 lay 22.3 percentage points below the measured number; measured number inside the range.
By their numbers in this assay, from the lowest: compound 1; then compound 3; then compound 2.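

In this assay, the gain seen at this position is not tied to the formyl group: the change to fluoro gives only a number 14.2 percentage points lower from compound 2 to compound 3 (beyond the scatter), a modest step, while the comparison with methoxy gives a number 60.7 percentage points higher from compound 1 to compound 3 (beyond the scatter), a large one. Compound 3 still reads 17.3% on the positive side, so among these three compounds, compound 2 and compound 3 show inhibition, and compound 1 is the one that goes the other way. The hydrogen-bond acceptor and the double bond of the formyl group are also not required for a positive number at this place on the aromatic ring, although compound 2 stands above compound 3 by more than the usual scatter.

The compounds shown leave open how an amine, a carboxylic acid, a nitrile or a longer chain such as ethoxy would read at this same place, and whether the order of the three would hold at other concentrations or in other cells. Nothing available here explains why these groups give such different numbers.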